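A naphthalen-1-yl swap on the carbonyl carbon

A few compounds are considered here, and "the series" means these few. Any claim that something is new, unique, unknown or untested is made for them only; others in the source may bear on it.

Measured in an ADME assay on MT4 cells (Homo sapiens) for cytotoxicity, read by MTT assay; a lower number here means that less compound is tolerated, a higher number that more compound is tolerated:
Compound 1 `O=C1c2ccccc2C(=O)N1CCOC(=S)N(C(=O)c1ccc(C(F)(F)F)cc1)c1ccc(Cl)cc1`: 10000 nM
Compound 2 `O=C1c2ccccc2C(=O)N1CCOC(=S)N(C(=O)c1c(F)cccc1F)c1ccc(Cl)cc1`: 39000 nM
Compound 3 `O=C1c2ccccc2C(=O)N1CCOC(=S)N(C(=O)c1cc([N+](=O)[O-])ccc1Cl)c1ccc(Cl)cc1`: 45000 nM

Compound 3 shares the top of this small range, with a 1.2-fold higher number from compound 2 to compound 3 (0.06 log units; within the scatter) and a 4.5-fold higher number from compound 1 to compound 3 (0.65 log units; beyond the scatter). Compound 4 `O=C1c2ccccc2C(=O)N1CCOC(=S)N(C(=O)c1cccc2ccccc12)c1ccc(Cl)cc1` carries naphthalen-1-yl in place of 2-chloro-5-nitrophenyl on a carbonyl carbon. All three measured steps change this same place, and the largest are modest, such as a 3.9-fold higher number from compound 1 to compound 2 (0.59 log units; beyond the scatter). Among the compounds with values here, no measured compound carries naphthalen-1-yl, so the guidance is only indirect. From the top of the range, a modest downward step or none is expected in this assay. The expected step is a 2.0-fold lower number from compound 3 to compound 4 (0.31 log units; beyond the scatter). Compound 4 is estimated at 22000 nM, within an expected range of 9000 nM to 55000 nM.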

Compound 4, half-maximal cytotoxic concentration: 6000 nM
Compound 4: middle estimate off by 3.7-fold (0.56 log units), on the high side, outside the stated range (below it).
By their numbers in this assay, from the lowest: compounds 4 and 1 (each within the scatter of the next); then compounds 2 and 3 (each within the scatter of the next).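

In this assay, naphthalen-1-yl on this carbonyl carbon gives a 7.5-fold lower number from compound 3 to compound 4 (0.88 log units; beyond the scatter) and a 6.5-fold lower number from compound 2 to compound 4 (0.81 log units; beyond the scatter) and so falls well away from the upper pair. Against the third comparison, a 1.7-fold lower number from compound 1 to compound 4 (0.22 log units; within the scatter) places compound 4 with compound 1, so the four groups at this position now form two pairs, with compound 2 and compound 3 the higher. Nothing at hand accounts for this split. The compounds shown leave open where naphthalen-2-yl or a saturated cyclohexyl ring would fall at this position. They also leave open whether the two pairs persist when a morpholine replaces the shared phthalimide-free end of the core.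

Correction to the final sentence: they also leave open whether the two pairs persist when an amine is carried on the aromatic ring at this same place.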